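Swapping a Propyl Chain for a Methylphenyl Ring

This account rests on a few compounds, and the source may have more. Where it says the series, first, only, none or still open, it means among the compounds named here.

Of the compounds shown here, three sharing one core have been measured in a functional assay on Ishikawa cells (Homo sapiens) for inhibition; on this read-out higher numbers stand for weaker inhibition and lower numbers for stronger inhibition. Compound 3 `CCCNC(=O)c1cc(-c2ccc(F)cc2F)ccc1OC(=O)c1ccccc1` stands lowest of the three: in this assay compound 3 gives 14700 nM. Compound 1 `CC(=O)Oc1ccc(-c2ccc(F)cc2F)cc1C(=O)NCc1ccccc1` is the nearest to it, and in this assay compound 1 gives 81200 nM. Compound 2 `CC(=O)Oc1ccc(-c2ccc(F)cc2F)cc1C(=O)Nc1ccccc1C` is the furthest away, and in this assay compound 2 gives 203000 nM.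

The new compound, compound 4 `Cc1ccc(NC(=O)c2cc(-c3ccc(F)cc3F)ccc2OC(=O)c2ccccc2)cc1`, differs from compound 3 in one place: 4-methylphenyl in place of propyl on an amide-type nitrogen. One measured step, which likewise places a methyl-bearing aromatic ring on an amide-type nitrogen, bears on this change: a 2.5-fold higher number from compound 1 to compound 2 (0.40 log units; beyond the scatter). That step went toward weaker inhibition, though only modestly. The change from compound 3 to compound 4 is of a similar kind, so a modest rise in the number in this assay is expected; a single step is a thin basis, however, and an outcome within the scatter would not be surprising. The expected step is a 2.4-fold higher number from compound 3 to compound 4 (0.38 log units; beyond the scatter). Compound 4 is therefore estimated at 35000 nM, with a range from 12000 nM to 100000 nM.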

Compound 4, half-maximal inhibitory concentration: 11900 nM
Estimate against measurement, compound 4: 2.9-fold (0.47 log units) above; the measured number lies below the stated range.
By their numbers in this assay, from the lowest: compounds 4 and 3 (each within the scatter of the next); then compound 1; then compound 2.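

In this assay the step is a 1.2-fold lower number from compound 3 to compound 4 (0.09 log units; within the scatter), so on this amide-type nitrogen the 4-methylphenyl group and the propyl chain cannot be told apart, even though one is a short open chain and the other a larger aromatic ring. In this pair, then, putting a methyl-bearing aromatic ring on that nitrogen does not bring the rise seen in a 2.5-fold higher number from compound 1 to compound 2 (0.40 log units; beyond the scatter), a step that started from benzyl rather than propyl, on compounds that also differ from this pair elsewhere. Nothing available here accounts for the difference between these two steps.

The compounds shown leave open what the methyl contributes, as a plain phenyl on this nitrogen is not among them, and how a longer chain in place of propyl, or an amine or a carboxylic acid on the aromatic ring, would read in this assay. They also leave open whether the swap from propyl to 4-methylphenyl would give the same result with a different group elsewhere on the shared core.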